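From 1H-imidazol-4-yl to thiophen-2-yl on compound 3

The compounds below may be only part of what the source reports. "The series", "measured", "known", "first", "only" and "open" are said of these compounds alone.

Measured in a functional assay on A-375 cells (Homo sapiens) for activation, with a stated time of 3 days; a higher number here means that more compound is needed for the effect, a lower number that less compound is needed:
- Compound 1 `O=C(NC1CCCN(Cc2ccc(F)c(F)c2)C1)c1ccc(-c2cscn2)cc1`: > 20000 nM (a limit of the assay, not a number)
- Compound 2 `O=C(Nc1ccc(-c2ccccc2)cc1)C1CCCN(Cc2ccc(F)c(F)c2)C1`: 5000 nM
- Compound 3 `O=C(Nc1ccc(-c2c[nH]cn2)cc1)C1CCCN(Cc2ccc(F)c(F)c2)C1`: 16000 nM

Among the results that are true numbers, compound 3, at 16000 nM, is the higher of the two, so more of it is needed for the effect. Its nearest neighbour is compound 2, at 5000 nM.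

The next compound to be tested is compound 4 `O=C(Nc1ccc(-c2cccs2)cc1)C1CCCN(Cc2ccc(F)c(F)c2)C1`. It carries thiophen-2-yl in place of 1H-imidazol-4-yl on an aromatic carbon, at a site para to a large group: thiophen-2-yl in place of 1H-imidazol-4-yl on an aromatic carbon.

Going by the values given here, one measured step bears on this change: a 3.2-fold higher number from compound 2 to compound 3 (0.51 log units; beyond the scatter), in which 1H-imidazol-4-yl took the place of phenyl at the same site. Compound 4 gives up that same 1H-imidazol-4-yl for another aromatic ring without it. A move back towards the number of compound 2 therefore seems likely, although thiophen-2-yl itself has not yet been tested here. A modest step to a lower number is expected in this assay. The estimated change is a 2.5-fold lower number from compound 3 to compound 4 (0.39 log units; beyond the scatter). For compound 4 the expected value is 6500 nM, with an estimated range from 2500 nM to 16000 nM.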

Compound 4, half-maximal effective concentration: 530 nM
Compound 4: middle estimate off by 12-fold (1.09 log units), on the high side; the whole stated range lies above it.
By their numbers in this assay, from the lowest: compound 4; then compound 2; then compound 3. At a limit, above all of these: compound 1.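

In this assay this site, on an aromatic carbon para to a large group, proves highly sensitive to the choice of ring: thiophen-2-yl in place of 1H-imidazol-4-yl brings a 30-fold lower number from compound 3 to compound 4 (1.48 log units; beyond the scatter) even though both groups have the same number of heavy atoms. Compound 4 is also more than a return to the level of the phenyl compound, since the change from phenyl to thiophen-2-yl gives a 9.4-fold lower number from compound 2 to compound 4 (0.97 log units; beyond the scatter) and so puts the two five-membered aromatic rings on opposite sides of phenyl. Nothing measured here explains this order of the three rings.

As far as these compounds go, it remains open whether other groups at this site, such as furan-2-yl, thiazol-2-yl or a simple amine, would follow thiophen-2-yl or 1H-imidazol-4-yl. Compound 1 gives > 20000 nM (a limit of the assay) and differs from the others in more than one place, so it cannot show how thiophen-2-yl would behave on a different core.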